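Fluoro in Place of Hydrogen on the Alkyne Phenyl

The source may report more compounds than this note shows. Statements on the series, on what has been measured and on what is new or still open speak of the compounds shown alone.

Compound 1, `COC(=O)c1sc2cc(C#Cc3ccc(OC)cc3)cnc2c1N`, gives 460 nM in a functional assay on MCF7 cells (Homo sapiens) for inhibition, read by sulforhodamine B assay, with a stated time of 48 h; on this read-out higher numbers stand for weaker inhibition of growth and lower numbers for stronger inhibition of growth.
Compound 2, `COC(=O)c1sc2cc(C#Cc3ccc(N)cc3)cnc2c1N`, gives 2600 nM.
Compound 3, `COC(=O)c1sc2cc(C#Cc3ccccc3)cnc2c1N`, gives only > 150000 nM.

Compound 3 sits at the limit of > 150000 nM in this assay, at which 1 of the 3 values shown sits, so its growth inhibition is bounded by a limit of the assay rather than measured as a number. Compound 4, `COC(=O)c1sc2cc(C#Cc3ccc(F)cc3)cnc2c1N`, differs from compound 3 by fluoro in place of hydrogen on an aromatic carbon. Among the measured compounds shown here, the steps that bear on this place are an at least 320-fold higher number from compound 1 to compound 3 (2.51 log units; beyond the scatter) and an at least 57-fold higher number from compound 2 to compound 3 (1.76 log units; beyond the scatter), both large, while a 5.7-fold higher number from compound 1 to compound 2 (0.75 log units; beyond the scatter) is modest. For the measured compounds named here, no measured step involves fluoro at this place, so only a modest change toward stronger inhibition is expected: an at least 1.5-fold lower number from compound 3 to compound 4 (0.17 log units; that floor lies within the scatter). Compound 4 is therefore estimated at 100000 nM, with a range from 20000 nM to 400000 nM, and may again be reported only as a limit.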

Compound 4, concentration for 50% growth inhibition: 29000 nM
Compound 4: the middle estimate sits 3.4-fold (0.54 log units) above what was measured; the measured number falls inside the stated range.
By their numbers in this assay, from the lowest: compound 1; then compound 2; then compound 4. At a limit, above all of these: compound 3.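

Fluoro in place of hydrogen on the phenyl already strengthens growth inhibition in this assay (an at least 5.1-fold lower number from compound 3 to compound 4 (0.71 log units; beyond the scatter)). Compound 3 is held only by a limit, not by a measured number: the limit of > 150000 nM in this assay, at which 1 of the 4 values shown sits. Fluoro still falls well short of the other two groups at this place (an 11-fold higher number from compound 2 to compound 4 (1.05 log units; beyond the scatter); a 63-fold higher number from compound 1 to compound 4 (1.80 log units; beyond the scatter)), so compound 4 gives the series a measured point at its weak end.

On these data alone, what chloro, hydroxy or the longer ethoxy would give at this place stays open. So does whether the same order of groups would hold on a different core.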